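Pyridine to Pyrazine Swap on a Second Core

The source may report more compounds than this note shows. Statements on the series, on what has been measured and on what is new or still open speak of the compounds shown alone.

Measured compounds, with their values in a functional assay on MDA-MB-231 cells (Homo sapiens) for antiproliferative activity, with a stated time of 72 h; on this read-out lower numbers stand for an effect already at smaller amounts and higher numbers for an effect only at larger amounts of compound:
Compound 1 `O=C([C@H]1CCN1S(=O)(=O)c1c(F)c(F)c(F)c(F)c1F)N(Cc1ccc(C2CCCCC2)cn1)c1ccc2c(=O)[nH]cnc2c1` gives 3300 nM.
Compound 2 `O=C([C@H]1CCN1S(=O)(=O)c1c(F)c(F)c(F)c(F)c1F)N(Cc1cnc(C2CCCCC2)cn1)c1ccc2c(=O)[nH]cnc2c1` gives 4200 nM.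
Compound 3 `O=C([C@H]1CCN1S(=O)(=O)c1c(F)c(F)c(F)c(F)c1F)N(Cc1ccc(C2CCCCC2)cn1)c1ccc2nn[nH]c2c1` gives 6600 nM.

Compounds 1 and 2 share a core and differ in one place: 5-cyclohexylpyrazin-2-yl in place of 5-cyclohexylpyridin-2-yl on a saturated chain carbon bound to an amide-type nitrogen. That change produced a 1.3-fold higher number from compound 1 to compound 2 (0.10 log units; within the scatter). Compound 3 carries the group of compound 1 on a different core; the two cores differ as follows: a group of 9 heavy atoms (6 carbon, 3 nitrogen; one five-membered aromatic ring with 3 hetero atoms, one six-membered aromatic ring of carbon only) in place of a group of 11 heavy atoms (8 carbon, 2 nitrogen, 1 oxygen; one six-membered aromatic ring of carbon only, one six-membered aromatic ring with 2 hetero atoms), on an amide-type nitrogen. That difference produced a 2.0-fold higher number from compound 1 to compound 3 (0.30 log units; within the scatter). All three numbers lie within the usual scatter of one another, so no order among them can be claimed.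

Compound 4 `O=C([C@H]1CCN1S(=O)(=O)c1c(F)c(F)c(F)c(F)c1F)N(Cc1cnc(C2CCCCC2)cn1)c1ccc2nn[nH]c2c1` has not been measured. Within the data shown here, it differs from compound 3 by 5-cyclohexylpyrazin-2-yl in place of 5-cyclohexylpyridin-2-yl on a saturated chain carbon bound to an amide-type nitrogen, the same change as the one from compound 1 to compound 2, at the same place. On that basis the step is expected to be small, about a 1.3-fold higher number from compound 3 to compound 4 (0.11 log units; within the scatter), because the matching step gave a 1.3-fold higher number from compound 1 to compound 2 (0.10 log units; within the scatter). Compound 4 is therefore estimated at 8600 nM, with a range from 4000 nM to 18000 nM, resting on one prior pair only.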

Compound 4, half-maximal effective concentration: 2100 nM
Estimate against measurement, compound 4: 4.1-fold (0.61 log units) above; the measured number lies below the stated range.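

In this assay, putting 5-cyclohexylpyrazin-2-yl in place of 5-cyclohexylpyridin-2-yl gave a 3.1-fold lower number from compound 3 to compound 4 (0.50 log units; beyond the scatter), yet the same swap on the core of compound 1 did not give a step beyond the scatter, so its outcome did not carry over from one core to the other: the same change on two cores in this assay, a 1.3-fold higher number (0.10 log units; within the scatter) from compound 1 to compound 2 and a 3.1-fold lower number (0.50 log units; beyond the scatter) from compound 3 to compound 4, 4.0-fold (0.60 log units) apart, beyond the scatter of two such steps. Read the other way, the change of core with the pyrazine group in place gave a 2.0-fold lower number from compound 2 to compound 4 (0.30 log units; within the scatter), which is within the scatter on its own but still differs from the matching step made with the pyridine group: the same change on two cores in this assay, a 2.0-fold higher number (0.30 log units; within the scatter) from compound 1 to compound 3 and a 2.0-fold lower number (0.30 log units; within the scatter) from compound 2 to compound 4, 4.0-fold (0.60 log units) apart, beyond the scatter of two such steps. Among these compounds, this shows that, for these four compounds, the effect of the swap depends on the core it sits on, but it does not show why, and with only one example per core it sets no general rule for the series.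

From the compounds shown here alone, it remains open whether a third core would behave like the core of compound 1 or like that of compound 3. Also open, going by these compounds, is whether the same dependence on the core would appear with an amine or a longer alkyl chain in place of the cyclohexyl ring.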